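This account rests on a few compounds, and the source may have more. Where it says the series, first, only, none or still open, it means among the compounds named here.

In a series of compounds sharing a fused bicyclic lactam core, compound 1 `O=C1Nc2c(ccc(F)c2F)C1(c1ccc(O)cc1)c1ccc(F)cc1` carries a 4-hydroxyphenyl and a 4-fluorophenyl group on the saturated ring carbon. In a functional assay on PC-3 cells (Homo sapiens) for cytotoxicity, read by WST assay, with a stated time of 72 h (on this read-out higher numbers stand for weaker inhibition and lower numbers for stronger inhibition), compound 1 gives 8.6 nM. Compound 2 `O=C1Nc2c(ccc(F)c2F)C1(c1ccc(O)cc1)C1CCCCCC1` is its counterpart in which the change cycloheptyl in place of 4-fluorophenyl on a saturated ring carbon has been made, and in this assay compound 2 gives 12 nM. The step of a 1.4-fold higher number from compound 1 to compound 2 (0.14 log units; within the scatter) therefore shows that the two compounds cannot be told apart on this read-out.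

Compound 3 `Cc1cc(C)c2c(c1)C(c1ccc(O)cc1)(c1ccc(F)cc1)C(=O)N2` is built on a different core, and the difference between the two cores is not broken down here. In this assay compound 3 gives 209 nM, the highest number of the three measured compounds, well beyond the scatter from both compound 1 and compound 2.

Compound 4 `Cc1cc(C)c2c(c1)C(c1ccc(O)cc1)(C1CCCCCC1)C(=O)N2` is the analogue of compound 3 obtained by the change (cycloheptyl in place of 4-fluorophenyl on a saturated ring carbon). This is the same change that was made between compound 1 and compound 2, at the same place on the same kind of saturated ring carbon. Because the earlier step of a 1.4-fold higher number from compound 1 to compound 2 (0.14 log units; within the scatter) stayed within the scatter, the step of a 1.2-fold higher number from compound 3 to compound 4 (0.09 log units; within the scatter) is expected to be of similar size. On that basis compound 4 is estimated to give 260 nM in this assay, with the likely range running from 120 nM to 560 nM.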

Compound 4, half-maximal inhibitory concentration: > 1000 nM
Compound 4 gave a limit, no number; the forecaster's own chance of this, stated with the estimate: 3%; at least 3.8-fold (0.58 log units) between middle value and limit.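

In this assay, the change to cycloheptyl in place of 4-fluorophenyl on a saturated ring carbon gives an at least 4.7-fold higher number from compound 3 to compound 4 (0.67 log units; beyond the scatter), and this step does not match the one seen for the same change on the core of compound 1: the same change on two cores in this assay, a 1.4-fold higher number (0.14 log units; within the scatter) from compound 1 to compound 2 and an at least 4.7-fold higher number (0.67 log units; beyond the scatter) from compound 3 to compound 4, at least 3.4-fold (0.53 log units) apart, beyond the scatter of two such steps

Compound 4 gives > 1000 nM, which is a limit of the assay and not a number, so the full size of the step cannot be read.

This shows that the outcome of the change did not carry over from the core of compound 1 to the core of compound 3, but two pairs give no rule for the series, and they do not show which part of the difference between the two cores matters.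

As far as these compounds go, whether a cyclopentyl or an n-butyl group in the same place would follow cycloheptyl on each of the two cores remains open. Also open, from the compounds shown here alone, is how this change would turn out on a core carrying chlorine in place of the two methyl groups of compound 3.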